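From phenyl to 3,4-dimethoxyphenyl on compound 3

A few compounds are considered here, and "the series" means these few. Any claim that something is new, unique, unknown or untested is made for them only; others in the source may bear on it.

In a functional assay on HOP-62 cells (Homo sapiens) for inhibition, read by sulforhodamine B assay (on this read-out lower numbers stand for stronger inhibition of growth and higher numbers for weaker inhibition of growth), compound 1 `c1ccc(-c2ccc(-c3ccc(-c4nc5ccccc5[nH]4)cc3)cc2)cc1` gives 100000 nM, and compound 2 `Cc1ccc2[nH]c(-c3ccc(-c4ccc(-c5ccc(N(C)C)cc5)cc4)cc3)nc2c1` gives 4230 nM. Compound 3 `Oc1cccc2[nH]c(-c3ccc(-c4ccc(-c5ccccc5)cc4)cc3)nc12` gives 9040 nM, the middle of these three numbers. For the measured compounds named here, the only measured step, an 11-fold lower number from compound 1 to compound 3 (1.04 log units; beyond the scatter), is large, but it comes from adding a hydroxy group and says nothing direct about the next change. Compound 4 `COc1ccc(-c2ccc(-c3ccc(-c4nc5c(O)cccc5[nH]4)cc3)cc2)cc1OC` keeps that hydroxy and differs from compound 3 as follows: 3,4-dimethoxyphenyl in place of phenyl on an aromatic carbon. In words, 3,4-dimethoxyphenyl stands in place of phenyl. Going by the values given here, no measured step tests this swap, so only a slight shift towards a lower number is expected, a 1.4-fold lower number from compound 3 to compound 4 (0.14 log units; within the scatter), which would stay within the scatter. For compound 4 the estimated value is 6500 nM, with an expected range of 1800 nM to 22000 nM.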

Compound 4, concentration for 50% growth inhibition: 2210 nM
Beside the measured number, compound 4's estimate is 2.9-fold (0.47 log units) above it; the measured number falls inside the stated range.
By their numbers in this assay, from the lowest: compounds 4 and 2 (each within the scatter of the next); then compound 3; then compound 1.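

In this assay, putting 3,4-dimethoxyphenyl in place of phenyl gives a 4.1-fold lower number from compound 3 to compound 4 (0.61 log units; beyond the scatter). So this far end of the molecule, para to a large group, also affects growth inhibition, and the larger ring with its two added hydrogen-bond acceptors is accepted with the hydroxy group kept. No available evidence explains the shift. Going by these compounds, it remains open whether one methoxy group alone would give the same step and whether the gain holds without the hydroxy group. On these data alone, a carboxylic acid or an ethoxy group on this ring also remains untested here.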